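Losing the dihydroxyphenyl group of compound 2

This account rests on a few compounds, and the source may have more. Where it says the series, first, only, none or still open, it means among the compounds named here.

compound 1 `COc1ccc(/C=C/C(=O)c2c(OC)cc(O)c(CC=C(C)C)c2O)cc1`: 38000 nM
compound 2 `COc1cc(O)c(CC=C(C)C)c(O)c1C(=O)/C=C/c1ccc(O)c(O)c1`: 16100 nM
compound 3 `COc1cc(/C=C/C(=O)c2c(OC)cc(O)c(CC=C(C)C)c2O)cc(OC)c1OC`: > 50000 nM

These values come from a functional assay on A549 cells (Homo sapiens) for inhibition, read by MTT assay, with a stated time of 72 h; a lower number here means a stronger inhibitor, a higher number a weaker inhibitor. Compound 3 gives only a limit, > 50000 nM, and not a number. Of the two true numbers, compound 2 holds the lower, 16100 nM.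

The next compound, compound 4 `COc1cc(O)c(CC=C(C)C)c(O)c1C(=O)/C=C/c1ccc([N+](=O)[O-])cc1`, changes compound 2 at one place, on a double-bonded chain carbon bound to a double-bonded chain carbon: 4-nitrophenyl in place of 3,4-dihydroxyphenyl on a double-bonded chain carbon bound to a double-bonded chain carbon.

For the measured compounds named here, one measured step bears on this place: a 2.4-fold lower number from compound 1 to compound 2 (0.37 log units; beyond the scatter). It is modest but beyond the scatter, and it brought in the 3,4-dihydroxyphenyl group that compound 4 gives up. A step of similar modest size in the opposite direction, towards a weaker inhibitor in this assay, therefore seems likely. Going by the values given here, no measured compound carries 4-nitrophenyl, so the range must stay wide.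

The expected change is a 1.7-fold higher number from compound 2 to compound 4 (0.24 log units; within the scatter). For compound 4 the estimated value is 28000 nM, with an expected range from 10000 nM to 60000 nM.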

Compound 4, half-maximal inhibitory concentration: 31200 nM
For compound 4 the middle estimate is 1.1-fold (0.05 log units) below the measured one, and the stated range covers the measured number.
By their numbers in this assay, from the lowest: compounds 2, 4 and 1 (each within the scatter of the next, the first and the last beyond it). At a limit, above all of these: compound 3.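

In this assay, 4-nitrophenyl in place of 3,4-dihydroxyphenyl gives a 1.9-fold higher number from compound 2 to compound 4 (0.29 log units; within the scatter), and nitro in place of methoxy on an aromatic carbon gives a 1.2-fold lower number from compound 1 to compound 4 (0.09 log units; within the scatter). Compound 4 therefore cannot be told apart from either compound, even though its new group has 0 hydrogen-bond donors against 2 in the group it replaces, and even though compound 1 and compound 2 differ from each other beyond the scatter. Nothing measured here explains this result.

Going by these compounds, it remains open whether the 3,4-dihydroxyphenyl group truly sets compound 2 apart, since compound 4 lies too close to both compounds to decide that. Also open, on these data alone, is how a 4-aminophenyl group or a phenyl ring bearing a carboxylic acid would behave at this place.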